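The source may hold more compounds than are shown below. What is called first, only, known or untested is meant among the compounds shown, and "the series" means these compounds.

Compounds measured so far:
- compound 1, `N#CC1=C(N)Oc2c(c3nc4ccccc4nc3c3ccccc23)C12C(=O)N(Cc1cnnn1-c1ccccc1Cl)c1ccccc12`: 42600 nM
- compound 2, `N#CC1=C(N)Oc2c(N)cc3nc4ccccc4nc3c2C12C(=O)N(Cc1cnnn1-c1cccc(C(F)(F)F)c1)c1ccccc12`: 5400 nM

Both numbers come from a functional assay on A549 cells (Homo sapiens) for antiproliferative activity, read by MTT assay, with a stated time of 48 h; a higher number here means a weaker inhibitor, a lower number a stronger inhibitor. Compound 1 gives 42600 nM, and compound 2 gives 5400 nM, the lower of the two numbers, so compound 2 is the stronger inhibitor of the pair, and the gap between the two lies beyond the usual scatter. The two compounds differ in more than one place, so the cause of that gap cannot be read from these two values alone.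

Compound 3, `Cc1cc(C)c(-n2nncc2CN2C(=O)C3(C(C#N)=C(N)Oc4c(N)cc5nc6ccccc6nc5c43)c3ccccc32)c(C)c1`, has not yet been measured. It differs from compound 2 in one place: 2,4,6-trimethylphenyl in place of 3-(trifluoromethyl)phenyl on an aromatic nitrogen

For the measured compounds named here, no measured pair shows what exchanging one group on this aromatic nitrogen for another does, so there is no step to lean on. Given that, the expected step of a 1.3-fold higher number from compound 2 to compound 3 (0.11 log units; within the scatter) is small, and any change is estimated to stay close to the scatter, with a slight lean toward a weaker inhibitor. The estimate for compound 3 in this assay is 7000 nM, within a range from 2000 nM to 25000 nM.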

Compound 3, half-maximal inhibitory concentration: 12700 nM
Compound 3: middle estimate off by 1.8-fold (0.26 log units), on the low side; measured number inside the range.
By their numbers in this assay, from the lowest: compound 2; then compound 3; then compound 1.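

In this assay, for the compounds shown here, putting 2,4,6-trimethylphenyl in place of 3-(trifluoromethyl)phenyl on the aromatic nitrogen of the five-membered ring gives a 2.4-fold higher number from compound 2 to compound 3 (0.37 log units; beyond the scatter), the first change that can be read at a single place. It shows that this nitrogen substituent can shift the number by a modest amount beyond the scatter, even though both groups are a single six-membered aromatic ring of carbon only, with no hydrogen-bond donors or acceptors and no net charge, so these counted features do not separate the two. Nothing measured here explains why the number rises with this exchange.

Going by these compounds alone, with only this one exchange to read, it stays open whether the step comes from losing the trifluoromethyl group or from gaining the three methyl groups, and a plain phenyl ring at the same nitrogen would help to separate the two. As far as these compounds go, it is also open how this position responds to a ring carrying an amine or a carboxylic acid, and compound 1 cannot settle any of this, since it differs from the other two compounds in more than one place.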